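The source may hold more compounds than are shown below. What is called first, only, known or untested is meant among the compounds shown, and "the series" means these compounds.

Compound 1 `O=c1oc2ccccc2n1CC1CCN(Cc2ccc(Cl)cc2)CC1` gives 0.1 nM in an assay on membranes from liver for displacement of a labelled ligand from Sigma non-opioid intracellular receptor 1 (Rattus norvegicus); on this read-out lower numbers stand for stronger inhibition and higher numbers for weaker inhibition. Compound 2 `O=c1oc2ccccc2n1CC1CCN(Cc2ccccc2F)CC1` gives 23 nM in this assay. Compound 3 `Cc1cc(C)c(CN2CCC(Cn3c(=O)oc4ccccc43)CC2)c(C)c1` gives 6230 nM in this assay.

Compound 1 stands lowest of the three numbers; its nearest neighbour is a 230-fold higher number from compound 1 to compound 2 (2.36 log units; beyond the scatter) and the furthest is a 62000-fold higher number from compound 1 to compound 3 (4.79 log units; beyond the scatter). Compound 4 `O=c1oc2ccccc2n1CC1CCN(Cc2ccc(-c3ccccc3)cc2)CC1` differs from compound 1 by phenyl in place of chloro on an aromatic carbon, para to a large group. Within the data shown here, no measured step alters that position alone; the two steps from compound 1 both replace the whole aryl group and were large, as were a 230-fold higher number from compound 1 to compound 2 (2.36 log units; beyond the scatter) and a 270-fold higher number from compound 2 to compound 3 (2.43 log units; beyond the scatter). The change to compound 4 keeps the ring and its attachment, so a modest rise in this assay is expected, a 10-fold higher number from compound 1 to compound 4 (1.00 log units; beyond the scatter). Compound 4 is therefore estimated at 1 nM, ranging from 0.1 nM to 12 nM.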

Compound 4, inhibition constant: 394 nM
The estimate for compound 4 lay 390-fold (2.60 log units) below the measured number, outside the stated range (above it).
By their numbers in this assay, from the lowest: compound 1; then compound 2; then compound 4; then compound 3.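

Until now, the aryl group had only been replaced as a whole; with compound 4, one substituent changes on an aromatic carbon, para to a large group, and phenyl in place of chloro gives a 3900-fold higher number from compound 1 to compound 4 (3.60 log units; beyond the scatter) in this assay. A change at this single position, with the rest of compound 1 kept, is therefore enough for a large step. Nothing measured here accounts for that step.

The compounds shown leave open how a methoxy group, an amine or a carboxylic acid at this position would read in this assay. As far as these compounds go, whether phenyl has a similar effect on other aryl groups also stays open.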